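This account rests on a few compounds, and the source may have more. Where it says the series, first, only, none or still open, it means among the compounds named here.

Measured compounds:
Compound 1, `Cc1nc(Cc2cccc(C(F)(F)F)c2)sc1-c1ccc(C(N)=O)cc1`, gives 93% in a functional assay on cells for agonist activity at G-protein coupled receptor 52 (Homo sapiens), read by AlphaScreen and cAMP accumulation, with a stated time of 30 min; a higher number here means a larger maximal response, a lower number a smaller maximal response.
Compound 2, `CCc1cc(-c2sc(Cc3cccc(C(F)(F)F)c3)nc2C)ccc1C(N)=O`, gives 84% in this assay.
Compound 3, `Cc1nc(Cc2cccc(C(F)(F)F)c2)sc1-c1ccc(C(N)=O)c(C(C)C)c1`, gives 63% in this assay.

Compound 3 stands lowest of the three numbers in this assay. The nearest number is that of compound 2, and the step of a number 21 percentage points lower from compound 2 to compound 3 (beyond the scatter) lies beyond the scatter; the furthest is that of compound 1, and the step of a number 30 percentage points lower from compound 1 to compound 3 (beyond the scatter) is likewise beyond the scatter. Between compound 1 and compound 2 the step of a number 9 percentage points lower from compound 1 to compound 2 (within the scatter) stays within the scatter.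

Compound 4, `COc1cc(-c2sc(Cc3cccc(C(F)(F)F)c3)nc2C)ccc1C(N)=O`, differs from compound 3 in one place: methoxy in place of isopropyl on an aromatic carbon. Going by the values given here, no measured step involves a methoxy, so the expectation rests on the three steps already seen. The step of a number 30 percentage points lower from compound 1 to compound 3 (beyond the scatter) and the step of a number 21 percentage points lower from compound 2 to compound 3 (beyond the scatter) both end at the isopropyl of compound 3 and both lowered the maximal response, whereas the step of a number 9 percentage points lower from compound 1 to compound 2 (within the scatter) shows that an ethyl on the same aromatic carbon changes nothing beyond the scatter. From the compounds shown here alone, with the isopropyl gone, a return toward the levels of compound 1 and compound 2 is expected, though the size of that return is uncertain since a methoxy of 2 heavy atoms is untested here. The step of a number 17 percentage points higher from compound 3 to compound 4 (beyond the scatter) is the expected outcome. Compound 4 is therefore estimated at 80% in this assay, with a range from 65% to 95%.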

Compound 4, largest response reached (Emax), in percent of the reference or control that the assay uses: 88%
Compound 4: middle estimate off by 8 percentage points, on the low side, within the range that was stated.
By their numbers in this assay, from the lowest: compound 3; then compounds 2, 4 and 1 (each within the scatter of the next).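

In this assay the step of a number 25 percentage points higher from compound 3 to compound 4 (beyond the scatter) shows that the loss of maximal response seen with isopropyl does not extend to every group on this aromatic carbon, ortho to a carbamoyl group. The steps of a number 5 percentage points lower from compound 1 to compound 4 (within the scatter) and a number 4 percentage points higher from compound 2 to compound 4 (within the scatter) place methoxy level with both hydrogen and ethyl at this position, so that among the four groups shown, only isopropyl stands apart, and the oxygen that methoxy brings, with its one hydrogen-bond acceptor, leaves no mark on the response that can be told from the scatter. Nothing available explains why isopropyl alone lowers the response while the other three groups do not.

From the compounds shown here alone, it remains open whether other groups on this carbon, such as a tert-butyl, a chlorine, a hydroxyl or an amine, would hold the response or lower it as isopropyl does. Going by these compounds, it is equally open whether methoxy would keep the response level with hydrogen if the trifluoromethyl elsewhere on the shared core gave way to a nitrile.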